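Methoxy for Methyl: What Compound 4 May Give

The source may hold more compounds than are shown below. What is called first, only, known or untested is meant among the compounds shown, and "the series" means these compounds.

Compound 3 `CNCc1ccc(C)c(-c2ccccc2OC)c1` gives 15 nM in an assay on HEK293 cells for displacement of a labelled ligand from 5-hydroxytryptamine receptor 7 (Homo sapiens), read by scintillation counting, with a stated time of 1.5 h, in the absence of a further agent (on this read-out lower numbers stand for stronger inhibition and higher numbers for weaker inhibition), the lowest of the three numbers shown; compound 2 `COc1ccccc1-c1cc(CN(C)C)ccc1Cl` gives 18 nM, within the scatter of that, while compound 1 `COc1ccccc1-c1cccc(CN(C)C)c1` gives 126 nM, beyond it. For the measured compounds named here, the single measured step, a 7.0-fold lower number from compound 1 to compound 2 (0.85 log units; beyond the scatter), concerns a different group at a different place. Compound 4 `CNCc1ccc(OC)c(-c2ccccc2OC)c1` differs from compound 3 by methoxy in place of methyl on an aromatic carbon. Going by the values given here, no measured step covers an exchange of methyl for methoxy, so neither direction nor size can be read from the data; the step between compound 1 and compound 2 shows only that a small change on this ring can move the number. The expected step is therefore small, a 1.7-fold higher number from compound 3 to compound 4 (0.22 log units; within the scatter). Compound 4 is estimated at 25 nM, ranging from 8 nM to 80 nM.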

Compound 4, inhibition constant: 648 nM
Compound 4: middle estimate off by 26-fold (1.41 log units), on the low side, and the stated range ends below it.
By their numbers in this assay, from the lowest: compounds 3 and 2 (each within the scatter of the next); then compound 1; then compound 4.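

The position para to the (methylamino)methyl group turns out to be sensitive to this exchange: in this assay, methoxy in place of methyl gives a 43-fold higher number from compound 3 to compound 4 (1.64 log units; beyond the scatter), far from a step inside the scatter. For the compounds shown here, the earlier compounds showed only that a change on this ring can move the number, whereas this pair gives the first direction and size for this exchange. Nothing at hand explains the change.

Going by these compounds, whether a hydroxyl, an ethoxy or an amine at this place would behave like methoxy or like methyl remains open. So does whether the exchange would cost as much with a dimethylamino group in place of the methylamino group.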